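Diethylamino in place of amino: splenocyte cytotoxicity notes

The compounds below may be only part of what the source reports. "The series", "measured", "known", "first", "only" and "open" are said of these compounds alone.

Measured so far:
compound 1 `CCCCCCCCCCCCCCC(N)CO`: 20.2%
compound 2 `CCCCCCCCCCCCCCC(CO)N(CC)CC`: 12.8%
compound 3 `CCCCCCCCCCCCCCC(CN)NC(=O)OC(C)(C)C`: 4.3%

In an ADME assay on cells (Splenocyte, Mus musculus, strain BALB/c) for cytotoxicity, read by MTT assay, tested at 10 ug/mL (a lower number here means a weaker effect, a higher number a stronger effect of the compound at the concentration tested), compound 1 gives 20.2%, compound 2 gives 12.8% and compound 3 gives 4.3%. Within the data shown here, the only counted step is a number 7.4 percentage points lower from compound 1 to compound 2 (within the scatter), made by diethylamino in place of amino on a saturated chain carbon bound to two saturated chain carbons. Compound 4 `CCCCCCCCCCCCCCC(CN(CC)CC)NC(=O)OC(C)(C)C` is not yet measured; it arises from compound 3 by diethylamino in place of amino on a saturated chain carbon, two bonds along the chain from an amide-type nitrogen. The surroundings differ: in the measured pair the change sits on a saturated chain carbon bound to two saturated chain carbons, in the new pair on a saturated chain carbon, two bonds along the chain from an amide-type nitrogen, so this is the same kind of change, not the same. The difference between the cores of compound 1 and compound 3 is not broken down here. The step of a number 1.3 percentage points lower from compound 3 to compound 4 (within the scatter) is expected to be small because a number 7.4 percentage points lower from compound 1 to compound 2 (within the scatter) lay within the scatter, and compound 3 already sits low. Compound 4 is therefore estimated at 3%, expected between 0% and 12%.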

Compound 4, a percentage reported as activity, at one concentration (the size of the read-out at that concentration, not a potency): 7.8%
Beside the measured number, compound 4's estimate is 4.8 percentage points below it; the measured number falls inside the stated range.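

In this assay, diethylamino in place of amino on a saturated chain carbon, two bonds along the chain from an amide-type nitrogen, gives a number 3.5 percentage points higher from compound 3 to compound 4 (within the scatter). Set beside the step on the core of compound 1, this gives no sign that the core alters the outcome of the change: the same change on two cores in this assay, a number 7.4 percentage points lower (within the scatter) from compound 1 to compound 2 and a number 3.5 percentage points higher (within the scatter) from compound 3 to compound 4, 10.9 percentage points apart, within the scatter of two such steps. Neither step lies beyond the scatter, so the pair does not show that the change has an effect of its own on either core, or that it would read alike on a third core.

The compounds shown leave open how dimethylamino or a carboxylic acid at the same carbon would read in this assay. As far as these compounds go, whether a shorter chain would alter either step also remains open.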